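Ester-bearing amine in place of diethylamino on the side chain

A few compounds are considered here, and "the series" means these few. Any claim that something is new, unique, unknown or untested is made for them only; others in the source may bear on it.

Of the compounds shown here, three sharing one core have been tested in a functional assay on MCF7 cells (Homo sapiens) for antiproliferative activity; on this read-out lower numbers stand for stronger inhibition and higher numbers for weaker inhibition. Compound 1 `CC(=O)Oc1ccc(C(=O)Nc2cc3ccc(OCC4CCCN(C)C4)c(C)c3oc2=O)cc1CC=C(C)C` gives 1650 nM, compound 2 `CC(C)=CCc1cc(C(=O)Nc2cc3ccc(OCCCN4CCCC4)c(C)c3oc2=O)ccc1O` gives 990 nM, and compound 3 `CCN(CC)CCCOc1ccc2cc(NC(=O)c3ccc(O)c(CC=C(C)C)c3)c(=O)oc2c1C` gives 6390 nM. Compound 3 therefore stands highest of the three numbers, with compound 1 nearest and compound 2 furthest from it, both gaps beyond the scatter.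

Compound 4 `COC(=O)CNCCCOc1ccc2cc(NC(=O)c3ccc(O)c(CC=C(C)C)c3)c(=O)oc2c1C` has not yet been measured. It differs from compound 3 in one place: ((methoxycarbonyl)methyl)amino in place of diethylamino on a saturated chain carbon, three bonds along the chain from an oxygen on an aromatic ring.

Going by the values given here, only one measured step bears on this position, the change of the amine on the same chain, which gave a 6.5-fold higher number from compound 2 to compound 3 (0.81 log units; beyond the scatter). That step shows the amine at this place can move this assay by a modest amount. Among the compounds with values here, no measured pair shows an amine carrying an ester, so the direction is uncertain. A modest step is expected, most likely a 1.3-fold higher number from compound 3 to compound 4 (0.10 log units; within the scatter), and compound 4 is estimated at 8000 nM, within a range of 2500 nM to 25000 nM.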

Compound 4, half-maximal inhibitory concentration: 2820 nM
For compound 4 the middle estimate is 2.8-fold (0.45 log units) above the measured one, within the range that was stated.
By their numbers in this assay, from the lowest: compounds 2, 1 and 4 (each within the scatter of the next, the first and the last beyond it); then compound 3.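

In this assay, an amine carrying an ester on this chain gives a lower number than diethylamino (a 2.3-fold lower number from compound 3 to compound 4 (0.36 log units; beyond the scatter)), yet it does not match pyrrolidin-1-yl (a 2.8-fold higher number from compound 2 to compound 4 (0.45 log units; beyond the scatter)). Among these three amines at this place, the numbers therefore run from pyrrolidin-1-yl through ((methoxycarbonyl)methyl)amino to diethylamino, with each gap beyond the scatter. Because the entering group brings both the ester and a hydrogen-bond donor on its nitrogen, the step cannot be assigned to either feature, and no measurement given here explains the order.

From the compounds shown here alone, it remains open whether a simple secondary amine such as ethylamino would give a similar number without the ester. The effect of a carboxylic acid in place of the methyl ester, or of a morpholine ring at the end of the chain, is also unresolved.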